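The compounds below may be only part of what the source reports. "The series", "measured", "known", "first", "only" and "open" are said of these compounds alone.

Measured compounds:
Compound 1, `COc1cc(-c2cc(/C=C/C(=O)c3ccc(N)cc3)[nH]n2)cc(OC)c1OC`: -90%
Compound 2, `COc1ccc(-c2cc(/C=C/C(=O)c3cc(OC)c(OC)c(OC)c3)[nH]n2)cc1OC`: -90%

In a functional assay on 786-0 cells (Homo sapiens) for cytotoxicity, read by sulforhodamine B assay, with a stated time of 48 h, tested at 100 uM (a lower number here means a stronger effect, a higher number a weaker effect of the compound at the concentration tested), compound 1 gives -90%, and in this assay compound 2 gives -90%. These two numbers are level at the digits shown; compound 1 stands within the usual scatter of compound 2, so no order between them can be claimed. Both readings point to a strong effect at the concentration tested.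

Compound 3, `COc1cc(-c2cc(/C=C/C(=O)c3ccc(F)c(F)c3)[nH]n2)cc(OC)c1OC`, has not yet been tested in this assay. It differs from compound 1 in one place: 3,4-difluorophenyl in place of 4-aminophenyl on a carbonyl carbon. Within the data shown here, no pair of measured compounds shows this kind of exchange, so its effect on the readout is not known from the data at hand.

The strong effect of compound 1 at -90% leaves little room for a move toward a stronger reading, so for compound 3 a modest step toward a weaker effect is expected, though with wide uncertainty. The estimated value for compound 3 in this assay is -75%, with a likely range from -95% to -35%. This estimate means an expected step of a number 15 percentage points higher from compound 1 to compound 3 (beyond the scatter).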

Compound 3, a percentage reported as activity, at one concentration (the size of the read-out at that concentration, not a potency): -47%
Beside the measured number, compound 3's estimate is 28 percentage points below it; the range from low to high includes it.
By their numbers in this assay, from the lowest: compounds 1 and 2 (each within the scatter of the next); then compound 3.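

Among these compounds, exchanging 4-aminophenyl for 3,4-difluorophenyl on the carbonyl carbon gives a number 43 percentage points higher from compound 1 to compound 3 (beyond the scatter) in this assay, the first step here that can be read across a single change. It shows that the reading at this position depends on which aryl group is present, something the two earlier compounds could not show, since they differ in more than one place. Nothing available explains why the reading moves.

This one exchange removes the amino group, with its hydrogen-bond donor and acceptor, and adds two fluorines, so the compounds shown cannot tell which part of the change matters. A plain phenyl or a 4-fluorophenyl at the same place would help separate the loss of the amine from the arrival of the fluorines.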